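The source may report more compounds than this note shows. Statements on the series, on what has been measured and on what is new or still open speak of the compounds shown alone.

The study compares three measured compounds and one awaiting measurement in a functional assay on the whole organism with Rattus norvegicus as the target; a lower number here means that less compound is needed, a higher number that more compound is needed for the effect. Compound 1 `Nc1nc2ccc(CC(F)(F)F)cc2s1` gives 8 mg/kg in this assay. Compound 2 `Nc1nc2ccc(OC(F)(F)C(F)(F)F)cc2s1` gives 2.5 mg/kg in this assay. Compound 3 `N=c1sc2cc(OC(F)(F)F)ccc2n1CCS(N)(=O)=O` gives 6 mg/kg in this assay, the second highest of the three numbers: compound 1 is its nearest neighbour, within the usual scatter, while compound 2 is the furthest from it, with a lower number that lies beyond the scatter.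

Compound 4 `C[S+]([O-])CCCn1c(=N)sc2cc(OC(F)(F)F)ccc21` has not yet been measured. It differs from compound 3 in one place: a group of 4 heavy atoms (2 carbon, 1 oxygen, 1 sulfur; no ring) in place of a group of 4 heavy atoms (1 nitrogen, 2 oxygen, 1 sulfur; no ring), on a saturated chain carbon, two bonds along the chain from an aromatic nitrogen. The group that leaves carries one hydrogen-bond donor and two hydrogen-bond acceptors; the group that enters carries no donor and one acceptor, and sits on the same saturated chain carbon, two bonds along the chain from the aromatic nitrogen.

Going by the values given here, no two measured compounds differ in only one place, so no measured step of this kind is available to guide the expectation. On that basis the step from compound 3 to compound 4 is estimated to be small in this assay, not beyond the scatter in either direction, as no change at the digits printed from compound 3 to compound 4 (within the scatter). Compound 4 is therefore expected to give about 6 mg/kg in this assay, with a likely range from 2.5 mg/kg to 15 mg/kg.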

Compound 4, dose for half-maximal effect: 2.3 mg/kg
Beside the measured number, compound 4's estimate is 2.6-fold (0.42 log units) above it; measured number below the stated range.
By their numbers in this assay, from the lowest: compounds 4 and 2 (each within the scatter of the next); then compounds 3 and 1 (each within the scatter of the next).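

In this assay, the saturated chain carbon two bonds along the chain from an aromatic nitrogen emerges as a place where the group matters: putting the group of 4 heavy atoms (2 carbon, 1 oxygen, 1 sulfur) in place of sulfamoyl gives a 2.6-fold lower number from compound 3 to compound 4 (0.42 log units; beyond the scatter). Going by these compounds alone, this is the only step here between compounds that differ in one place, and since the entering group carries 0 hydrogen-bond donors, a donor in this place is not needed to reach a low number. Nothing measured here accounts for the step.

The compounds shown leave open whether this lower number would hold on another core, as this single pair offers no second comparison. They also leave open how an amine, a carboxylic acid or a longer chain in this place would compare in this assay.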